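The source may hold more compounds than are shown below. What is called first, only, known or untested is meant among the compounds shown, and "the series" means these compounds.

For the measured compounds named here, compound 2 `COc1ccc(CN2CCC(N3CC(c4ccnc5ccc(OC)cc45)OC3=O)CC2)cc1` gives 1260 nM in an in vitro functional assay on RBL cells for antagonist activity at C-C chemokine receptor type 8 (Homo sapiens), read by FLIPR and calcium flux (on this read-out higher numbers stand for weaker inhibition and lower numbers for stronger inhibition), the highest of the two numbers so far; its nearest neighbour is compound 1 `CCCCCCN1CCC(N2CC(c3ccnc4ccc(OC)cc34)OC2=O)CC1`, which gives 501 nM. Going by the values given here, the one step seen, a 2.5-fold higher number from compound 1 to compound 2 (0.40 log units; beyond the scatter), comes from putting 4-methoxyphenyl in place of pentyl on a saturated chain carbon bound to an amine nitrogen in a ring. Compound 3 `COc1ccc2nccc(C3CN(C4CCN(C(=O)c5ccc(Cl)c(Cl)c5)CC4)C(=O)O3)c2c1` differs from compound 2 by (3,4-dichlorophenyl)carbonyl in place of 4-methoxybenzyl on an amine nitrogen in a ring. The step from compound 1 to compound 2 touches the same nitrogen but swaps only the chain end, so it gives scant guidance on a carbonyl entering there. For compound 3 the step of a 1.2-fold higher number from compound 2 to compound 3 (0.08 log units; within the scatter) is therefore expected to be small and uncertain in direction. Compound 3 is estimated at 1500 nM, within a range of 300 nM to 8000 nM.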

Compound 3, half-maximal inhibitory concentration: 6310 nM
Compound 3: the middle estimate sits 4.2-fold (0.62 log units) below what was measured; the range from low to high includes it.
By their numbers in this assay, from the lowest: compound 1; then compound 2; then compound 3.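

In this assay, the step of a 5.0-fold higher number from compound 2 to compound 3 (0.70 log units; beyond the scatter) shows that the amine nitrogen in the six-membered ring can also take a group joined through a carbonyl, but at a cost beyond the scatter. The wider step a 13-fold higher number from compound 1 to compound 3 (1.10 log units; beyond the scatter), with (3,4-dichlorophenyl)carbonyl in place of hexyl, is large, and compound 3 gives the highest number of the three, so it is the weakest inhibitor here. Nothing available explains why this substitution weakens inhibition.

The carbonyl and the two chlorine atoms enter together, so the compounds shown cannot separate their contributions; 3,4-dichlorobenzyl or (4-methoxyphenyl)carbonyl on this nitrogen would divide the change into its parts. As far as these compounds go, whether a longer chain on this nitrogen would give a lower number than hexyl also remains open.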